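The source may report more compounds than this note shows. Statements on the series, on what has been measured and on what is new or still open speak of the compounds shown alone.

Working notes on the series. In a functional assay on BXPC-3 cells (Homo sapiens) for antiproliferative activity, read by MTT assay, with a stated time of 24 h (on this read-out higher numbers stand for weaker inhibition and lower numbers for stronger inhibition), compound 1 `CCn1c(C(=O)N[C@@H](C)CO)ccc1C(CC)(CC)c1ccc(OCS(=O)(=O)c2ccccc2)c(C)c1` gives 15300 nM and compound 2 `CCn1c(C(=O)N[C@H](CO)C(C)C)ccc1C(CC)(CC)c1ccc(OCS(=O)(=O)c2ccccc2)c(C)c1` gives 7720 nM. Among the measured compounds shown here, the only measured step between them is a 2.0-fold lower number from compound 1 to compound 2 (0.30 log units; within the scatter), so compound 2 stands level with compound 1 on these numbers.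

Compound 3 `CCn1c(C(=O)N[C@H](CO)CCCO)ccc1C(CC)(CC)c1ccc(OCS(=O)(=O)c2ccccc2)c(C)c1` is the next case. It carries 3-hydroxypropyl in place of isopropyl on a saturated chain carbon bound to an amide-type nitrogen and a saturated chain carbon.

The step from compound 1 to compound 2 bears on this change, since it altered the group at the same place, and its size stayed within the scatter. It is thin evidence: a single step, between two groups without a hydroxyl. For the measured compounds named here, no measured compound shows what a chain ending in a hydroxyl does here. In this assay, no step beyond the scatter is therefore expected, and the range is kept wide. The expected step is a 1.2-fold higher number from compound 2 to compound 3 (0.09 log units; within the scatter). For compound 3 the estimated value is 9500 nM, with an expected range of 4000 nM to 23000 nM.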

Compound 3, half-maximal inhibitory concentration: > 50000 nM
Compound 3 was reported as a limit; the forecaster's own chance of this, stated with the estimate: 8%; middle value at least 5.2-fold (0.72 log units) away from the limit.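

The position on the saturated chain carbon bound to an amide-type nitrogen and a saturated chain carbon is not indifferent to what it carries: 3-hydroxypropyl in place of isopropyl gives an at least 6.4-fold higher number from compound 2 to compound 3 (0.81 log units; beyond the scatter), and the same compound read against the methyl case, as 2-hydroxyethyl in place of hydrogen on a saturated chain carbon, two bonds along the chain from an amide-type nitrogen, gives an at least 3.2-fold higher number from compound 1 to compound 3 (0.51 log units; beyond the scatter). The methyl and isopropyl compounds had stayed within the scatter of each other, so only the hydroxyl-ending chain shows that a change here can carry a step beyond it in the direction of weaker inhibition. In this assay compound 3 is reported only as a limit, so both steps are lower bounds on a size that cannot be read: the limit of > 50000 nM in this assay, at which 1 of the 3 values shown sits.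

The compounds shown do not separate the terminal hydroxyl from the chain itself, and a plain propyl chain at this place would set the two apart. As far as these compounds go, whether the loss extends to other chain ends, such as an amine or a carboxylic acid, or to a shorter hydroxymethyl group, also remains open.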